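Three Fluorines in Place of a Methoxy Group

The source may hold more compounds than are shown below. What is called first, only, known or untested is meant among the compounds shown, and "the series" means these compounds.

Compound 3, `COc1ccc(Nc2ncnc3cc(OC)c(OCCCCC(=O)Nc4ccc(S(N)(=O)=O)cc4)cc23)cc1`, carries a 4-methoxyphenyl group on the nitrogen of a shared core. In a functional assay on A549 cells (Homo sapiens) for antiproliferative activity, read by MTT assay, with a stated time of 72 h (on this read-out lower numbers stand for stronger inhibition and higher numbers for weaker inhibition), compound 3 reaches only the assay limit of > 40000 nM, so its true number is not known. Two neighbours frame where it stands. Compound 1, `C#Cc1cccc(Nc2ncnc3cc(OC)c(OCCCCC(=O)Nc4ccc(S(N)(=O)=O)cc4)cc23)c1`, gives 7720 nM in this assay. Compound 2, `COc1cc2ncnc(Nc3cccc(F)c3)c2cc1OCCCCC(=O)Nc1ccc(S(N)(=O)=O)cc1`, reaches only the limit of > 40000 nM in this assay. The step that speaks most directly here is an at least 5.1-fold higher number from compound 1 to compound 3 (0.71 log units; beyond the scatter), which shows that exchanging the group on that nitrogen can move the number by a large margin. The step that the two limits leave unreadable from compound 2 to compound 3 cannot be sized, since both values sit at the limit of > 40000 nM in this assay, at which 2 of the 3 values shown sit.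

Compound 4, `COc1cc2ncnc(Nc3cc(F)c(F)c(F)c3)c2cc1OCCCCC(=O)Nc1ccc(S(N)(=O)=O)cc1`, differs from compound 3 in one place: 3,4,5-trifluorophenyl in place of 4-methoxyphenyl on a nitrogen on an aromatic ring. Compound 2, with a single fluoro on the same ring, already sits at the limit, so nothing seen so far points to a gain. The step of a number no higher from compound 3 to compound 4 (the limit leaves the size open) is therefore expected to be small. Compound 4 is estimated at 40000 nM, somewhere between 12000 nM and 100000 nM, most likely again reported only as a limit.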

Compound 4, half-maximal inhibitory concentration: > 40000 nM
Compound 4 was reported as a limit; the forecaster's own chance of this, stated with the estimate: 65%; the middle value lies on the limit itself.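

With 3,4,5-trifluorophenyl on the nitrogen, compound 4 joins compound 2 and compound 3 at the assay limit, so neither three fluorines, one fluorine nor a 4-methoxyphenyl ring gives a readable number in this assay: the limit of > 40000 nM in this assay, at which 3 of the 4 values shown sit. The one step that can be read is an at least 5.1-fold higher number from compound 1 to compound 4 (0.71 log units; beyond the scatter), which leaves the 3-ethynylphenyl group of compound 1 as the only group shown on this nitrogen with a measured number. The steps among compound 2, compound 3 and compound 4 cannot be read, as each joins two limits.

On these data alone, how far these three compounds lie past the limit stays open. The compounds shown also do not tell whether a nitrile or an ethyl group in place of the ethynyl group would keep a readable number.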